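Benzylsulfonyl variation on a shared core: from fluorines to nitrile

The compounds below may be only part of what the source reports. "The series", "measured", "known", "first", "only" and "open" are said of these compounds alone.

Measured compounds:
- compound 1, `N#Cc1cc2c(nc1N1CCC(C(=O)NS(=O)(=O)Cc3ccccc3F)CC1)COC2=O`: 23700 nM
- compound 2, `CC(c1ccccc1)S(=O)(=O)NC(=O)C1CCN(c2nc3c(cc2C#N)C(=O)OC3)CC1`: 4160 nM
- compound 3, `N#Cc1cc2c(nc1N1CCC(C(=O)NS(=O)(=O)Cc3ccc(F)cc3F)CC1)COC2=O`: 5200 nM

In a functional assay (Platelet, plasma) for inhibition, with Homo sapiens as the target (on this read-out higher numbers stand for weaker inhibition and lower numbers for stronger inhibition), compound 3 gives 5200 nM, the second highest of the three numbers. Its nearest neighbour is compound 2, whose value in this assay is 4160 nM; the step of a 1.3-fold higher number from compound 2 to compound 3 (0.10 log units; within the scatter) lies within the scatter, so no order can be read between the two. Compound 1 stands furthest away, and the step of a 4.6-fold lower number from compound 1 to compound 3 (0.66 log units; beyond the scatter) shows that a single fluoro on the benzyl ring brought the number down modestly.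

Compound 4, `N#Cc1ccc(CS(=O)(=O)NC(=O)C2CCN(c3nc4c(cc3C#N)C(=O)OC4)CC2)cc1`, differs from compound 3 in one place: 4-cyanophenyl in place of 2,4-difluorophenyl on a saturated chain carbon bound to a sulfonyl sulfur

Going by the values given here, no measured step involves a nitrile on this ring, so the bearing evidence is indirect. The step of a 4.6-fold lower number from compound 1 to compound 3 (0.66 log units; beyond the scatter) shows that fluorines on this benzyl ring lowered the number; removing both of them points back toward compound 1, while the step of a 5.7-fold lower number from compound 1 to compound 2 (0.76 log units; beyond the scatter) shows that other groups on the sulfonyl sulfur can also lower it. Compound 4 is therefore expected to give a somewhat higher number than compound 3, with the estimated step of a 1.7-fold higher number from compound 3 to compound 4 (0.24 log units; within the scatter) close to the scatter. The estimate for compound 4 is 9000 nM, ranging from 3000 nM to 30000 nM.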

Compound 4, half-maximal inhibitory concentration: 8900 nM
For compound 4 the middle estimate is 1.0-fold (0.00 log units) above the measured one; the range from low to high includes it.
By their numbers in this assay, from the lowest: compounds 2, 3 and 4 (each within the scatter of the next, the first and the last beyond it); then compound 1.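

In this assay a ring with a nitrile and no fluorine can stand on the saturated chain carbon bound to a sulfonyl sulfur without a readable difference from the difluorinated ring, the step being a 1.7-fold higher number from compound 3 to compound 4 (0.23 log units; within the scatter); the step of a 2.7-fold lower number from compound 1 to compound 4 (0.43 log units; beyond the scatter) then shows that 4-cyanophenyl, like 2,4-difluorophenyl, gives a lower number than 2-fluorophenyl, so among these compounds a second fluorine is not the only ring change that lowers the number. The unbranched 4-cyanobenzyl group does not, however, match 1-phenylethyl, as the step of a 2.1-fold higher number from compound 2 to compound 4 (0.33 log units; beyond the scatter) lies beyond the scatter, even though 2,4-difluorobenzyl and 4-cyanobenzyl cannot be separated from each other. Nothing in the material given explains why these groups fall in this order.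

Still open, as far as these compounds go, is whether the number of compound 4 belongs to the nitrile itself or to the absence of fluorine on the ring. Also open, from the compounds shown here alone, is how a carboxylic acid or an amine on this ring, or a longer chain in place of the saturated chain carbon bound to a sulfonyl sulfur, would read in this assay.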